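Swapping Methyl for Methoxy: Expected Cytotoxicity of Compound 4

The source may hold more compounds than are shown below. What is called first, only, known or untested is meant among the compounds shown, and "the series" means these compounds.

Measured compounds:
- Compound 1, `N#Cc1ccc(NC(=O)c2cc(Cc3ccccc3)ccc2O)cc1`: 1740 nM
- Compound 2, `N#Cc1ccc(NC(=O)c2cc(Br)ccc2O)cc1`: 620 nM
- Compound 3, `Cc1ccc(O)c(C(=O)Nc2ccc(C#N)cc2)c1`: 3920 nM

All three compounds share one core and differ only in the group on one aromatic carbon. In a functional assay on HL-60 cells (Homo sapiens) for cytotoxicity, read by luminescence and CellTiter-Glo, with a stated time of 3 days (on this read-out lower numbers stand for stronger inhibition and higher numbers for weaker inhibition), compound 3 gives 3920 nM, the highest number of the three: a 2.3-fold higher number from compound 1 to compound 3 (0.35 log units; beyond the scatter) and a 6.3-fold higher number from compound 2 to compound 3 (0.80 log units; beyond the scatter) both go beyond the scatter, so compound 3 is the weakest of the measured set.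

Compound 4, `COc1ccc(O)c(C(=O)Nc2ccc(C#N)cc2)c1`, has not been measured. It differs from compound 3 as follows: methoxy in place of methyl on an aromatic carbon.

Among the measured compounds shown here, no measured step swaps methyl for methoxy, so the data give no direct guide. For the measured compounds named here, the nearest precedent is a 6.3-fold higher number from compound 2 to compound 3 (0.80 log units; beyond the scatter), which shows that a change of the small group on this aromatic carbon can move the number by a modest amount. Given that, compound 4 is expected to stay close to compound 3, with a step of a 1.2-fold lower number from compound 3 to compound 4 (0.09 log units; within the scatter), likely inside the scatter. The estimate for compound 4 in this assay is 3200 nM, with a range from 1200 nM to 8500 nM.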

Compound 4, half-maximal inhibitory concentration: > 10000 nM
Compound 4: no number, only a limit (the forecaster's own chance of this, stated with the estimate: 5%); middle value at least 3.1-fold (0.49 log units) from the limit.
By their numbers in this assay, from the lowest: compound 2; then compound 1; then compound 3. At a limit, above all of these: compound 4.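

In this assay compound 4 gives no number, only a limit of the assay: the limit of > 10000 nM in this assay, at which 1 of the 4 values shown sits. Even so, the steps can be read as minimum sizes: an at least 2.5-fold higher number from compound 3 to compound 4 (0.40 log units; beyond the scatter) and an at least 5.7-fold higher number from compound 1 to compound 4 (0.75 log units; beyond the scatter) are both beyond the scatter, and an at least 16-fold higher number from compound 2 to compound 4 (1.20 log units; beyond the scatter) is a large one, which makes compound 4 the weakest of the four. So a swap as small as methoxy in place of methyl, para to the hydroxy group, can cost real activity here, while the bulkier benzyl of compound 1 still gives a measured number, so the number does not simply follow the size of the group.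

As far as these compounds go, how far compound 4 lies past its limit stays unknown, so the true size of these steps is open. Whether an ethoxy group or an amine on this carbon would also reach the limit cannot be told from these compounds.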